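Chloro added to the second phenyl of compound 2

A few compounds are considered here, and "the series" means these few. Any claim that something is new, unique, unknown or untested is made for them only; others in the source may bear on it.

Compound 1 `CC1=C(C(=O)Nc2ccccc2)C(c2cn(-c3ccccc3)nc2-c2ccccc2)NC(=S)N1`, compound 2 `COc1ccc(NC(=O)C2=C(C)NC(=S)NC2c2cn(-c3ccccc3)nc2-c2ccccc2)cc1` and compound 3 `CC1=C(C(=O)Nc2ccc(Cl)cc2)C(c2cn(-c3ccccc3)nc2-c2ccccc2)NC(=S)N1` share one core and differ in a single aromatic substituent. In a functional assay on MCF7 cells (Homo sapiens) for inhibition, read by sulforhodamine B assay, with a stated time of 24 h (a lower number here means a stronger inhibitor of growth, a higher number a weaker inhibitor of growth), compound 1 gives 88200 nM, compound 2 gives 77300 nM and compound 3 gives 34700 nM. Compound 2 stands second highest of the three: a 1.1-fold lower number from compound 1 to compound 2 (0.06 log units; within the scatter) lies within the scatter, whereas a 2.2-fold lower number from compound 2 to compound 3 (0.35 log units; beyond the scatter) and a 2.5-fold lower number from compound 1 to compound 3 (0.41 log units; beyond the scatter) are modest but beyond it. Compound 4 `COc1ccc(NC(=O)C2=C(C)NC(=S)NC2c2cn(-c3ccccc3)nc2-c2ccc(Cl)cc2)cc1` keeps the methoxy of compound 2 and carries one further change: chloro in place of hydrogen on an aromatic carbon. Among the measured compounds shown here, no measured step places a chloro on this ring of the core; the nearest analogies are a 2.5-fold lower number from compound 1 to compound 3 (0.41 log units; beyond the scatter) and a 2.2-fold lower number from compound 2 to compound 3 (0.35 log units; beyond the scatter), each a chloro entering on an aromatic carbon and each lowering the number modestly. Carried over with caution, a small lowering is expected for compound 4, possibly no larger than the scatter. Compound 4 is therefore estimated at 50000 nM, with a range of 25000 nM to 110000 nM. For compound 4 this estimate means the step of a 1.5-fold lower number from compound 2 to compound 4 (0.19 log units; within the scatter).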

Compound 4, concentration for 50% growth inhibition: 70000 nM
For compound 4 the middle estimate is 1.4-fold (0.15 log units) below the measured one; the measured number falls inside the stated range.
By their numbers in this assay, from the lowest: compounds 3, 4, 2 and 1 (each within the scatter of the next, the first and the last beyond it).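

In this assay, the phenyl to 4-chlorophenyl change, para to a large group, gives a 1.1-fold lower number from compound 2 to compound 4 (0.04 log units; within the scatter), so this position shows no response to chloro that can be told from the scatter in this single pair. Among the compounds shown here, compound 4 therefore goes against any reading that chloro on an aromatic carbon lowers the number throughout the series, as the only chloro-for-hydrogen step beyond the scatter is the one ending at compound 3. Even so, the two chloro steps cannot be told apart, so no real dependence on the position or the core is shown: the same change on two cores in this assay, a 2.5-fold lower number (0.41 log units; beyond the scatter) from compound 1 to compound 3 and a 1.1-fold lower number (0.04 log units; within the scatter) from compound 2 to compound 4, 2.3-fold (0.36 log units) apart, within the scatter of two such steps.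

From the compounds shown here alone, whether a different group at this place, such as an amine or a carboxylic acid, would move the number beyond the scatter remains open. Also open, going by these compounds, is how the same chloro would read on the core of compound 1 or of compound 3.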